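The source may hold more compounds than are shown below. What is called first, only, known or untested is meant among the compounds shown, and "the series" means these compounds.

Measured compounds:
Compound 1 `O=C(N/N=C/c1ccc(O)cc1)c1ccc(-c2nc3ccccc3s2)cc1` — 11300 nM
Compound 2 `O=C(N/N=C/c1cccc(O)c1O)c1ccc(-c2nc3ccccc3s2)cc1` — 11200 nM
Compound 3 `O=C(N/N=C/c1ccccc1O)c1ccc(-c2nc3ccccc3s2)cc1` — 5550 nM

All three share the same core and differ only in the aryl group on the carbon with a double bond to nitrogen. Within the data shown here, in an assay on isolated protein for inhibition of Maltase-glucoamylase (Homo sapiens), with a stated time of 15 min (a lower number here means a stronger inhibitor, a higher number a weaker inhibitor), compound 3 gives the lowest of the three numbers, though its nearest neighbour is compound 2, whose value lies within the scatter of it; only the step of a 2.0-fold lower number from compound 1 to compound 3 (0.31 log units; beyond the scatter) is beyond the scatter, and that step is modest.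

Compound 4 `COC(=O)c1ccc(/C=N/NC(=O)c2ccc(-c3nc4ccccc4s3)cc2)cc1` is not yet measured in this assay. Its change from compound 3 is 4-(methoxycarbonyl)phenyl in place of 2-hydroxyphenyl on a carbon with a double bond to nitrogen. The step that bears most on it is a 2.0-fold lower number from compound 1 to compound 3 (0.31 log units; beyond the scatter), since compound 1 also carries its substituent on the position that is not the 2-position; that step is small, and a 2.0-fold lower number from compound 2 to compound 3 (0.30 log units; within the scatter) is within the scatter. Among the measured compounds shown here, no measured compound carries a 4-(methoxycarbonyl)phenyl, so the expectation rests on these small steps alone. Compound 4 is therefore expected to give a number close to compound 1 or compound 3, with the step of a 1.6-fold higher number from compound 3 to compound 4 (0.21 log units; within the scatter) expected to be small. The estimate for compound 4 is 9000 nM, with a range from 3000 nM to 30000 nM.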

Compound 4, half-maximal inhibitory concentration: "not active" (no number reported)
No number was reported for compound 4, so the estimate cannot be set against anything.
By their numbers in this assay, from the lowest: compounds 3, 2 and 1 (each within the scatter of the next, the first and the last beyond it).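

In this assay, among these compounds, compound 4 is reported as not active, without a number, so no step from it to compound 1, compound 2 or compound 3 can be read. The compounds shown leave open how far the 4-(methoxycarbonyl)phenyl group moves the number. No evidence given here bears on this result.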